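Second chloro on the benzyl group of compound 1

The source may hold more compounds than are shown below. What is called first, only, known or untested is meant among the compounds shown, and "the series" means these compounds.

In a functional assay on MDA-MB-231 cells (Homo sapiens) for cytotoxicity, read by MTT assay, with a stated time of 72 h (on this read-out lower numbers stand for stronger inhibition and higher numbers for weaker inhibition), compound 1 (`CCN(CC)Cc1ccc2nc(NC(=O)N/N=C/c3cn(Cc4ccc(Cl)cc4)c4ccccc34)sc2c1`) gives 2570 nM and sits level with compound 2 (`CC1CCN(Cc2ccc3nc(NC(=O)N/N=C/c4cn(Cc5ccc(Cl)cc5)c5ccccc45)sc3c2)CC1`) at 2850 nM within the scatter. That single measured step (a 1.1-fold higher number from compound 1 to compound 2 (0.04 log units; within the scatter)) puts 4-methylpiperidin-1-yl in place of diethylamino. Compound 3 (`CCN(CC)Cc1ccc2nc(NC(=O)N/N=C/c3cn(Cc4ccc(Cl)c(Cl)c4)c4ccccc34)sc2c1`) instead takes chloro in place of hydrogen on an aromatic carbon, 4-chlorobenzyl to 3,4-dichlorobenzyl (chloro in place of hydrogen on an aromatic carbon). For the measured compounds named here, no measured step touches this group, so the data give neither size nor direction, and no shift beyond the scatter is expected (a 1.1-fold lower number from compound 1 to compound 3 (0.03 log units; within the scatter)). The estimate for compound 3 is 2400 nM in this assay (expected range 1000 nM to 5500 nM).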

Compound 3, half-maximal inhibitory concentration: 4490 nM
Compound 3: middle estimate off by 1.9-fold (0.27 log units), on the low side, and the stated range covers the measured number.
By their numbers in this assay, from the lowest: compounds 1, 2 and 3 (each within the scatter of the next).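

In this assay, for the compounds shown here, the one step on the benzyl group, 4-chlorobenzyl to 3,4-dichlorobenzyl, reads (a 1.7-fold higher number from compound 1 to compound 3 (0.24 log units; within the scatter)). A second chloro ortho to the chloro group therefore brings no shift beyond the scatter, which the amine step alone could not show. No measured evidence bears on this result.

As far as these compounds go, whether a methoxy group or a fluoro at this position would read the same remains open. So does the effect of this second chloro with the 4-methylpiperidin-1-yl group of compound 2.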